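This account rests on a few compounds, and the source may have more. Where it says the series, first, only, none or still open, it means among the compounds named here.

Measured in an assay for inhibition of Fatty-acid amide hydrolase 1 (Rattus norvegicus), using a Dixon plot; a lower number here means a stronger inhibitor, a higher number a weaker inhibitor:
compound 1 `COC(=O)c1ccc(-c2cnc(C(=O)CCCCCCc3ccccc3)o2)nc1` gives 3.1 nM;
compound 2 `C[S+]([O-])/C=C/c1ccc(-c2cnc(C(=O)CCCCCCc3ccccc3)o2)nc1` gives 3 nM;
compound 3 `O=C(O)CCCCc1cnc(C(=O)CCCCCCc2ccccc2)o1` gives 23.8 nM.

Compound 3 has the highest number of the three in this assay; compound 1 and compound 2 both lie beyond the scatter from it, and they lie together, as a 1.0-fold lower number from compound 1 to compound 2 (0.01 log units; within the scatter) shows. That step swaps one group for another on an aromatic carbon and says nothing about the saturated chain of compound 3, which is where the change to compound 4 `O=C(CCCCCCc1ccccc1)c1ncc(CCCCCO)o1` takes place: hydroxymethyl in place of carboxy on a saturated chain carbon, four bonds along the chain from an aromatic carbon. Within the data shown here, no measured pair in this set shares that change, so no step bears on it directly. Among the measured compounds shown here, the one change tried elsewhere left the number essentially unchanged, and there is nothing in the data to suggest that trading a carboxy for a hydroxymethyl at the end of the chain should move compound 4 far from compound 3. The expected step is a 1.2-fold lower number from compound 3 to compound 4 (0.08 log units; within the scatter), not beyond the scatter in either direction. Compound 4 is therefore estimated in this assay at 20 nM, within a range from 7 nM to 60 nM.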

Compound 4, inhibition constant: 10.1 nM
For compound 4 the middle estimate is 2.0-fold (0.30 log units) above the measured one; the measured number falls inside the stated range.
By their numbers in this assay, from the lowest: compounds 2 and 1 (each within the scatter of the next); then compound 4; then compound 3.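

In this assay, the place on the saturated chain, four bonds along the chain from an aromatic carbon, proves responsive to the group it carries: hydroxymethyl in place of carboxy gives a modest shift towards a stronger inhibitor (a 2.4-fold lower number from compound 3 to compound 4 (0.37 log units; beyond the scatter)). Among these compounds, this is the first measured change at this place, and it shows that the number can move beyond the scatter even though the carboxy and the hydroxymethyl count the same hydrogen-bond donors and acceptors and neither carries a net charge. Among the compounds shown here, the only earlier step, a 1.0-fold lower number from compound 1 to compound 2 (0.01 log units; within the scatter), was on an aromatic carbon and stayed within the scatter, so it gave no sign of how this saturated chain would respond.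

The compounds shown leave open whether an amine or a methyl ester at this place would read closer to compound 3 or to compound 4, and whether a longer chain bearing the same hydroxymethyl would keep the step. No measurement at hand offers an explanation for the size or direction of this step.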